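Changing the aryl group on the urea of a piperidine scaffold

The source may hold more compounds than are shown below. What is called first, only, known or untested is meant among the compounds shown, and "the series" means these compounds.

Compound 1, `CN(C)C1(Cc2ccccc2)CCN(c2cc(C(F)(F)F)ccc2CNC(=O)Nc2ccc(NS(C)(=O)=O)c(F)c2)CC1`: 1160 nM
Compound 2, `CN(C)C1(Cc2ccccc2)CCN(c2cc(C(F)(F)F)ccc2CNC(=O)Nc2ccc(CNS(N)(=O)=O)c(F)c2)CC1`: 15.3 nM

Going by the values given here, in an assay on CHO cells for displacement of a labelled ligand from transient receptor potential cation channel subfamily V member 1 (Homo sapiens), read by scintillation counting, with a stated time of 60 min (on this read-out lower numbers stand for stronger inhibition and higher numbers for weaker inhibition), compound 1 stands at the higher of the two numbers; its only neighbour, compound 2, sits a 76-fold lower number from compound 1 to compound 2 (1.88 log units; beyond the scatter). Compound 3, `CN(C)C1(Cc2ccccc2)CCN(c2cc(C(F)(F)F)ccc2CNC(=O)Nc2ccc3c(c2)OCC3)CC1`, carries the change a group of 9 heavy atoms (8 carbon, 1 oxygen; one five-membered non-aromatic ring with 1 hetero atom, one six-membered aromatic ring of carbon only) in place of a group of 12 heavy atoms (7 carbon, 1 nitrogen, 2 oxygen, 1 fluorine, 1 sulfur; one six-membered aromatic ring of carbon only), on an amide-type nitrogen: the 3-fluoro-4-(methanesulfonamido)phenyl leaves and a bicyclic group with no hydrogen-bond donor enters. Among the compounds with values here, no measured step covers this change; the one step known, from compound 1 to compound 2, only shows that the same part of the shared core moves the number strongly. A step of a 1.3-fold higher number from compound 1 to compound 3 (0.11 log units; within the scatter) is therefore expected, with wide uncertainty. Compound 3 is estimated at 1500 nM, between 300 nM and 7500 nM.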

Compound 3, inhibition constant: 41.4 nM
The estimate for compound 3 lay 36-fold (1.56 log units) above the measured number, outside the stated range (below it).
By their numbers in this assay, from the lowest: compound 2; then compound 3; then compound 1.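

Putting the bicyclic group in place of the 3-fluoro-4-(methanesulfonamido)phenyl on the amide-type nitrogen gives a 28-fold lower number from compound 1 to compound 3 (1.45 log units; beyond the scatter) in this assay. At this position, then, a group with 0 hydrogen-bond donors and no sulfur or fluorine reads far lower than the methanesulfonamide of compound 1, so the sulfonamide hydrogen-bond donor is not required for a low number. Nothing available accounts for the size of this step.

From the compounds shown here alone, whether the ring oxygen of compound 3 contributes remains open. So does how a plain phenyl or a 4-aminophenyl group would read on the same nitrogen.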